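A few compounds are considered here, and "the series" means these few. Any claim that something is new, unique, unknown or untested is made for them only; others in the source may bear on it.

Compound 1 `COc1cc2nc(NCc3ccccc3)nc(NC3CCCCCC3)c2cc1OC` was examined in an in vitro assay on B300-19 cells for displacement of a labelled ligand from C-C chemokine receptor type 4 (Homo sapiens), tested at 1 uM; on this read-out higher numbers stand for more inhibition at the one concentration tested (going by the name of the read-out) and lower numbers for less inhibition. In this assay compound 1 gives only a limit, < 0%. Compound 2 `COc1cc2nc(N3CCC(N4CCCC4)CC3)nc(N(C)C)c2cc1OC` likewise gives only a limit in this assay, < 0%. Compound 3 `COc1cc2nc(N3CCC(N4CCCC4)CC3)nc(NCc3ccccc3)c2cc1OC` also reaches only a limit in this assay, < 0%. The step between these two cannot be read: a step that the two limits leave unreadable from compound 2 to compound 3. Within the data shown here, all three values share (the limit of < 0% in this assay, at which 3 of the 3 values shown sit); no measured step shows how a change at the amine alters displacement. Compound 4 `COc1cc2nc(NC(C)C)nc(NC3CCCCCC3)c2cc1OC` differs from compound 1 by isopropyl in place of benzyl on a nitrogen on an aromatic ring. Among the measured compounds shown here, no measured step bears on this change; nothing beyond the scatter is foreseen. Compound 4 is expected to give 0%, within -10% to 12%. The expected step is a number no lower from compound 1 to compound 4 (the limit leaves the size open).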

Compound 4, a percentage reported as inhibition, at one concentration (the size of the read-out at that concentration, not a potency): 6%
Compound 4: middle estimate off by 6 percentage points, on the low side; the range from low to high includes it.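

Among these compounds, compound 4 is the first compound here to give a number rather than a limit in this assay, so the change on this nitrogen can be partly read. Putting isopropyl in place of benzyl is a number at least 6 percentage points higher from compound 1 to compound 4 (that floor lies within the scatter), so losing the aromatic ring of benzyl at this place brings no loss of inhibition. Almost all the values still sit at one floor: the limit of < 0% in this assay, at which 3 of the 4 values shown sit.

On these data alone, whether an amine or a carboxylic acid on a longer chain in place of isopropyl would give inhibition clearly beyond the scatter stays open.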